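Changing the Amide Substituent: Only Limits So Far

The source may report more compounds than this note shows. Statements on the series, on what has been measured and on what is new or still open speak of the compounds shown alone.

Compound 1 `COc1ccc2c(=O)c(/C=C/C(=O)Nc3cccc(C)c3)coc2c1`: in a functional assay on L02 cells (Homo sapiens) for inhibition, read by MTT assay, with a stated time of 48 h (on this read-out lower numbers stand for stronger inhibition and higher numbers for weaker inhibition), compound 1 gives > 200000 nM, which is a limit of the assay and not a number.
Compound 2 `COc1ccc2c(=O)c(/C=C/C(=O)NCc3cccc(F)c3)coc2c1`: in this assay compound 2 gives > 200000 nM, again a limit.
Compound 3 `COc1ccc2c(=O)c(/C=C/C(=O)Nc3ccccc3OC)coc2c1`: in this assay compound 3 gives > 200000 nM, again a limit.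

Compound 1 thus stands only at a limit, as do the two other measured compounds, all of which sit together at the limit of > 200000 nM in this assay, at which 3 of the 3 values shown sit. The change now considered leads to compound 4 `COc1ccc2c(=O)c(/C=C/C(=O)NCc3ccc(F)cc3F)coc2c1`, a compound that differs from compound 1 in one place: 2,4-difluorobenzyl in place of 3-methylphenyl on an amide-type nitrogen. The measured steps that bear on this change are a step that the two limits leave unreadable from compound 1 to compound 2 and a step that the two limits leave unreadable from compound 1 to compound 3, and the third, a step that the two limits leave unreadable from compound 2 to compound 3, is no more readable. None of them gives a direction or a size, so no step beyond the scatter can be expected in either direction, and a further limit is the most likely outcome. Compound 4 is therefore estimated to give 200000 nM, with a range from 50000 nM to 400000 nM. The expected step is a number no higher from compound 1 to compound 4 (the limit leaves the size open).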

Compound 4, half-maximal inhibitory concentration: > 200000 nM
Compound 4: only a limit was reported (the forecaster's own chance of this, stated with the estimate: 80%); the middle value lies on the limit itself.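

Compound 4 is again only a limit, so its steps from compound 1, compound 2 and compound 3 cannot be read, and all four compounds stay together: the limit of > 200000 nM in this assay, at which 4 of the 4 values shown sit. The compounds shown leave open whether any amide substituent gives a real number in this assay at all.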